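Cyclopropylamino for (6-hydroxyhexyl)amino: expectation for compound 4

The compounds below may be only part of what the source reports. "The series", "measured", "known", "first", "only" and "open" are said of these compounds alone.

Compound 1 `CCn1cnc2c(NC(=N)N)nc(N)nc21`: 54300 nM
Compound 2 `N=C(N)Nc1nc(N)nc2c1ncn2CCO`: > 100000 nM, a limit of the assay the limit of > 100000 nM in this assay, at which 1 of the 3 values shown sits.
Compound 3 `CC(C)n1cnc2c(NC(=N)N)nc(NCCCCCCO)nc21`: 5200 nM

In a functional assay on MCF7 cells (Homo sapiens) for inhibition, read by fluorescence, with a stated time of 72 h (a lower number here means a stronger inhibitor, a higher number a weaker inhibitor), compound 3 has the lowest number of the two that are numbers; the nearest is compound 1 with 54300 nM, a gap beyond the scatter. Compound 2 gives only a limit.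

Compound 4 `CC(C)n1cnc2c(NC(=N)N)nc(NC3CC3)nc21` differs from compound 3 by cyclopropyl in place of 6-hydroxyhexyl on a nitrogen on an aromatic ring. Among the compounds with values here, the only measured step with any bearing is the one adding a hydroxy on a chain carbon, an at least 1.8-fold higher number from compound 1 to compound 2 (0.26 log units; that floor lies within the scatter), which runs toward weaker inhibition but with a floor inside the scatter and ending at a limit. Here the hydroxy leaves together with the whole chain, so that step gives no firm direction; no measured pair changes the chain length or adds a ring. The expectation for compound 4 is therefore a number near that of compound 3, the step of a 1.2-fold lower number from compound 3 to compound 4 (0.06 log units; within the scatter) within the scatter. Compound 4 is estimated at 4500 nM, between 1500 nM and 14000 nM.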

Compound 4, half-maximal inhibitory concentration: 5400 nM
Beside the measured number, compound 4's estimate is 1.2-fold (0.08 log units) below it, and the stated range covers the measured number.
By their numbers in this assay, from the lowest: compounds 3 and 4 (each within the scatter of the next); then compound 1. At a limit, above all of these: compound 2.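

The step in this assay reads a 1.0-fold higher number from compound 3 to compound 4 (0.02 log units; within the scatter) and shows no readable change when cyclopropyl replaces 6-hydroxyhexyl on this nitrogen on an aromatic ring. For this one pair, the open chain of 7 heavy atoms with its hydrogen-bond donor and acceptor can give way to a three-membered ring of 3 carbon atoms, with neither donor nor acceptor, and the number stays within the scatter. Nothing measured here gives a cause for this result.

On these data alone, whether an amine, a carboxylic acid or a longer chain at this nitrogen would shift the number remains open. A plain hexyl group, without the hydroxy, would be needed to separate any part played by the hydroxy from that of the chain itself.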